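A furan replaces a fluorobenzyl on an inactive series

The source may report more compounds than this note shows. Statements on the series, on what has been measured and on what is new or still open speak of the compounds shown alone.

Three close relatives share one core. Compound 1 `CCOC(=O)c1cccc(-c2n[nH]c3ccccc23)c1` carries no group on the ring nitrogen. Compound 2 `CCOC(=O)c1ccc(-c2nn(Cc3cccc(F)c3)c3ccccc23)cc1` carries a 3-fluorobenzyl group there, and compound 3 `CCOC(=O)c1ccc(-c2nn(Cc3cccc(OC)c3)c3ccccc23)cc1` a 3-methoxybenzyl group. All three were tested in a functional assay on cells (Platelet, Homo sapiens) for inhibition; on this read-out lower numbers stand for stronger inhibition and higher numbers for weaker inhibition. Compound 1 reaches only a limit of the assay, > 10000 nM. Compound 2 likewise shows only a limit, > 10000 nM. Compound 3 too shows only a limit, > 10000 nM. Among the compounds with values here, the single step that joins two of them, a step that the two limits leave unreadable from compound 2 to compound 3, therefore carries no readable size. The whole of the evidence is the limit of > 10000 nM in this assay, at which 3 of the 3 values shown sit.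

Compound 4 `CCOC(=O)c1ccc(-c2nn(-c3ccco3)c3ccccc23)cc1` is the compound not yet measured; from compound 2 it differs by furan-2-yl in place of 3-fluorobenzyl on an aromatic nitrogen. Within the data shown here, no measured step bears on this change in a readable way: the only step measured is unreadable. Compound 2 sits at the limit, as do both of its companions. On that footing compound 4 is expected to stay at or near the limit, and the estimated step that the limit leaves unreadable from compound 2 to compound 4 is expected to be none beyond the scatter. Compound 4 is thus estimated at 20000 nM, with a range from 5000 nM to 100000 nM.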

Compound 4, half-maximal inhibitory concentration: > 10000 nM
Compound 4: no number, only a limit (the forecaster's own chance of this, stated with the estimate: 80%); the middle value is on the limit's open side.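

Compound 4 also reaches only a limit, and the steps joining it to compound 2 and compound 3 cannot be read. The compounds shown leave open whether any group on that ring nitrogen of the shared core can give a measurable value in this assay.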